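Benzoyl substituent removal in the pyrazole anilide series

This account rests on a few compounds, and the source may have more. Where it says the series, first, only, none or still open, it means among the compounds named here.

Compound 2 `COc1cc(-c2nn(-c3cccc(NC(=O)c4cccc(C(F)(F)F)c4)c3)cc2-c2ccncc2)ccc1Cl` gives 1320 nM in a functional assay on MDA-MB-468 cells (Homo sapiens) for inhibition, read by sulforhodamine B assay, with a stated time of 48 h (a higher number here means a weaker inhibitor of growth, a lower number a stronger inhibitor of growth), the second highest of the three numbers recorded. Compound 1 `COc1cc(-c2nn(-c3cccc(NC(=O)c4ccc(Cl)c(C(F)(F)F)c4)c3)cc2-c2ccncc2)ccc1Cl` stands nearest, at 3690 nM; the single-point step from compound 1 to compound 2, hydrogen in place of chloro on an aromatic carbon, reads a 2.8-fold lower number from compound 1 to compound 2 (0.45 log units; beyond the scatter). Among the measured compounds shown here, compound 3 `O=C(Nc1cccc(-n2cc(-c3ccncc3)c(-c3ccc(Cl)c(O)c3)n2)c1)Nc1cc(C(F)(F)F)cc(C(F)(F)F)c1`, a urea carrying two trifluoromethyl groups and hydroxy in place of methoxy, gives 265 nM; it differs from compound 2 in more than one place, so no single step connects the two.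

Compound 4 `COc1cc(-c2nn(-c3cccc(NC(=O)c4ccccc4)c3)cc2-c2ccncc2)ccc1Cl` continues the stripping of the benzoyl ring: hydrogen in place of trifluoromethyl on an aromatic carbon. For the measured compounds named here, the only measured step that bears on this is the one from compound 1 to compound 2, where removing a chloro from the same ring lowered the number. Whether removing the trifluoromethyl as well goes the same way is open; compound 3, with two trifluoromethyl groups, gives the lowest number of the set, which counts against further gains from a bare benzoyl. The step of a 1.5-fold higher number from compound 2 to compound 4 (0.18 log units; within the scatter) is therefore expected to be small, within or near the scatter, leaning toward a higher number. Compound 4 is estimated at 2000 nM, between 700 nM and 6000 nM.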

Compound 4, concentration for 50% growth inhibition: 349 nM
Estimate against measurement, compound 4: 5.7-fold (0.76 log units) above; the whole stated range lies above it.
By their numbers in this assay, from the lowest: compounds 3 and 4 (each within the scatter of the next); then compound 2; then compound 1.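

In this assay, the trifluoromethyl on the benzoyl ring of compound 2 proves dispensable for growth inhibition: its replacement by hydrogen gives a 3.8-fold lower number from compound 2 to compound 4 (0.58 log units; beyond the scatter) and so extends the direction seen when chloro was removed. The two removals add up to the full change from 4-chloro-3-(trifluoromethyl)phenyl to phenyl, which gives an 11-fold lower number from compound 1 to compound 4 (1.02 log units; beyond the scatter) and is the largest step within this amide group, so across compound 1, compound 2 and compound 4 each substituent taken from the ring lowers the number, with none of the three going against this. No measurement at hand accounts for this trend.

On these data alone, whether hydrogen is the best choice at this carbon or merely better than trifluoromethyl stays open, and a fluoro, a methyl, an amine or a carboxylic acid in the same place would help to separate those readings. Compound 3 differs from compound 4 in more than one place, so the separate contributions of its urea, hydroxy and two trifluoromethyl groups also remain unresolved.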